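The compounds below may be only part of what the source reports. "The series", "measured", "known", "first", "only" and "open" are said of these compounds alone.

Of the compounds shown here, three built on the same shared core have been tested in an assay on isolated protein for inhibition of hexokinase-3 (Rattus norvegicus), with a stated time of 6 h, tested at 10 mM; a lower number here means less inhibition, a higher number more inhibition at the concentration tested (going by the name of the read-out). Compound 1 `CN(CCCCN(C)C(=O)CCCCNc1ncnc2c1ncn2[C@@H]1O[C@H](COP(=O)(O)OP(=O)(O)OP(=O)(O)O)[C@@H](O)[C@H]1O)C(=O)CCCCNC(=O)CI` gives 0% in this assay. Compound 2 `O=C(CI)NCCCCC(=O)NCCCCCCNc1ncnc2c1ncn2[C@@H]1O[C@H](COP(=O)(O)OP(=O)(O)OP(=O)(O)O)[C@@H](O)[C@H]1O` gives 0% in this assay. Compound 3 `CN(CCCCN(C)c1ncnc2c1ncn2[C@@H]1O[C@H](COP(=O)(O)OP(=O)(O)OP(=O)(O)O)[C@@H](O)[C@H]1O)C(=O)CCCCCNC(=O)CI` gives 0% in this assay. Compound 2 thus stands level with compounds 1 and 3 at the digits reported: its nearest neighbour on the numbers is compound 1 and its furthest is compound 3, and neither gap goes beyond the usual scatter of this kind of measurement. In effect none of the three shows inhibition at the concentration used.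

Compound 4 `O=C(CI)NCCC(=O)NCCCCCCNc1ncnc2c1ncn2[C@@H]1O[C@H](COP(=O)(O)OP(=O)(O)OP(=O)(O)O)[C@@H](O)[C@H]1O` has not yet been measured. It is derived from compound 2 by a single change: ((iodomethyl)carbonyl)amino in place of 2-(((iodomethyl)carbonyl)amino)ethyl on a saturated chain carbon, two bonds along the chain from a carbonyl carbon. The ((iodomethyl)carbonyl)amino end is kept, and the saturated chain that carries it is made shorter.

Within the data shown here, no step between measured compounds is available to calibrate a change of this kind. Because compound 2 gives 0% and compounds 1 and 3 sit at the same place, the shortening is expected to leave the value where it is. The step of no change at the digits printed from compound 2 to compound 4 (within the scatter) is expected to be none beyond the scatter. Compound 4 is therefore estimated at 0% in this assay, with a range from -8% to 10%.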

Compound 4, a percentage reported as inhibition, at one concentration (the size of the read-out at that concentration, not a potency): 0%
Beside the measured number, compound 4's estimate shows no gap at the digits printed, and the stated range covers the measured number.
By their numbers in this assay, from the lowest: compounds 1, 2, 3 and 4 (each within the scatter of the next).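

In this assay, among these compounds, putting ((iodomethyl)carbonyl)amino in place of 2-(((iodomethyl)carbonyl)amino)ethyl on a saturated chain carbon, two bonds along the chain from a carbonyl carbon, gives no change at the digits printed from compound 2 to compound 4 (within the scatter); this is the first step at this position that can be read, and shortening the chain that carries the ((iodomethyl)carbonyl)amino end does not bring any inhibition into view. The step has limited reach, however: compound 2 already stands at 0%, so a read-out at this level could not show a loss, and the result does not tell whether the length of this chain matters for inhibition. No other measurement bears on why the value stays flat here.

Still open, as far as these compounds go, is whether a longer chain at this position, or an amine or a carboxylic acid in place of the ((iodomethyl)carbonyl)amino end, would lift the read-out clear of the scatter. Until a compound on the shared core shows measurable inhibition in this assay, the effect of a change at this position has no non-zero starting value against which it can be judged.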